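The source may hold more compounds than are shown below. What is called first, only, known or untested is meant among the compounds shown, and "the series" means these compounds.

- compound 1 `COc1ccc2c(c1)-c1cnc(n1C)OCCCCCCCCO2` gives 57000 nM
- compound 2 `Cn1c2cnc1OCCCCCCCCCOc1ccccc1-2` gives 72000 nM
- compound 3 `CCCCOc1ncc(-c2ccccc2OC)n1C` gives 82000 nM

In a functional assay on SK-MEL-28 cells (Homo sapiens) for inhibition, read by colorimetric assay and MTT assay, with a stated time of 72 h (a higher number here means a weaker inhibitor, a lower number a stronger inhibitor), compound 3, at 82000 nM, lies within the scatter of both compound 1 and compound 2, so the three values do not separate. Compound 4 (`COc1ccccc1-c1cnc(OC)n1C`) differs from compound 3 by a single change (hydrogen in place of propyl on a saturated chain carbon bound to an oxygen on an aromatic ring): hydrogen in place of propyl on a saturated chain carbon bound to an oxygen on an aromatic ring, which turns butoxy to methoxy. For the measured compounds named here, no two measured compounds differ in one place, so the data give no direct measure of such a change. Compound 1 at 57000 nM and compound 2 at 72000 nM both remain within the scatter of compound 3, and that is the only basis for expecting little movement. The expected step is a 1.1-fold higher number from compound 3 to compound 4 (0.04 log units; within the scatter) and is not expected to go beyond the scatter, with a slight lean toward a higher number. Compound 4 is estimated at 90000 nM with an expected range of 45000 nM to 180000 nM as its span.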

Compound 4, half-maximal inhibitory concentration: > 100000 nM
Compound 4 ended at the assay's limit; the forecaster's own chance of this, stated with the estimate: 35%; middle value at least 1.1-fold (0.04 log units) from the limit.
By their numbers in this assay, from the lowest: compounds 1, 2 and 3 (each within the scatter of the next). At a limit, above all of these: compound 4.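

Replacing butoxy with methoxy in this assay gives the first direct measure of a change at this position, an at least 1.2-fold higher number from compound 3 to compound 4 (0.08 log units; that floor lies within the scatter). Going by these compounds, compound 4 stands at a limit of the assay, so this step is only a floor: shortening the chain did not bring the number down, but the size of any rise is unknown, and the floor does not go beyond the scatter. The reading therefore cannot be placed more exactly on this scale: the limit of > 100000 nM in this assay, at which 1 of the 4 values shown sits.

On these data alone, whether a longer chain, an amine or a carboxylic acid in place of the butoxy would give a lower number remains open. So does whether the change from butoxy to methoxy would have a comparable outcome on the core of another compound.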